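The source may report more compounds than this note shows. Statements on the series, on what has been measured and on what is new or still open speak of the compounds shown alone.

Measured compounds:
Compound 1 `Cc1nc(C(=O)N2CCC3(CC3)C[C@H]2CNc2ccc(Cl)cn2)c(-c2ccccc2)s1`: in a functional assay on CHO cells for antagonist activity at Orexin/Hypocretin receptor type 1 (Homo sapiens), read by FLIPR and calcium flux (a higher number here means a more potent compound, by a factor of ten per unit of this negative logarithm, a lower number a less potent compound), compound 1 gives 7.9.
Compound 2 `O=C(c1nc(C(F)(F)F)ccc1-c1ncccn1)N1CC2(CC2)C[C@H]1CNc1ccc(C(F)(F)F)cn1`: in this assay compound 2 gives 6.7.
Compound 3 `Cc1ccc(-c2ccccc2)c(C(=O)N2CC3(CC3)C[C@H]2CNc2ccc(C(F)(F)F)cn2)n1`: in this assay compound 3 gives 8.6.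

Compound 2 stands lowest of the three numbers. Compound 1 sits higher by a margin beyond the scatter, and compound 3 sits higher still, also beyond the scatter. Going by the values given here, no pair of measured compounds differs in a single place, so no measured step is available to calibrate the change toward the next compound; the three compounds differ from one another in several places at once.

Compound 4 `O=C(c1nc(OC(F)(F)F)ccc1-c1ncccn1)N1CC2(CC2)C[C@H]1CNc1ccc(C(F)(F)F)cn1` differs from compound 2 in one place: trifluoromethoxy in place of trifluoromethyl on an aromatic carbon. The swap keeps the count of heavy atoms nearly the same and adds one hydrogen-bond acceptor, with no change in charge or donors. In this assay the step is expected to be small, with no clear direction, and most likely not beyond the scatter. The step of a number 0.10 log units higher from compound 2 to compound 4 (within the scatter) is estimated to be near zero. Compound 4 is thus expected to give 6.8, in a range from 6.3 to 7.3.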

Compound 4, negative logarithm of the antagonist equilibrium constant: 7
Compound 4: middle estimate off by 0.20 log units, on the low side; measured number inside the range.
By their numbers in this assay, from the lowest: compounds 2 and 4 (each within the scatter of the next); then compound 1; then compound 3.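

Going by these compounds alone, this is the first single-place comparison: in this assay, trifluoromethoxy in place of trifluoromethyl on the aromatic carbon next to the ring nitrogen, para to the pyrimidin-2-yl group, gives a number 0.30 log units higher from compound 2 to compound 4 (within the scatter). At this place, then, compound 2 and compound 4 cannot be told apart, even though the entering group carries a hydrogen-bond acceptor that the leaving group lacks. No measurement on hand bears on why the two compounds read alike.

This single pair says nothing about how far the finding extends to other groups: an amine, a carboxylic acid or a nitrile on the same carbon could read quite differently. Also open, as far as these compounds go, is whether the same swap gives a similar result at the second trifluoromethyl group of compound 2.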